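Chloro in Place of Methyl: Expected Cytotoxicity of Compound 3

The source may report more compounds than this note shows. Statements on the series, on what has been measured and on what is new or still open speak of the compounds shown alone.

Among the compounds with values here, compound 2 `Cc1cccc2sc(Nn3c(-c4ccc([N+](=O)[O-])cc4)nnc3-c3cccnc3)nc12` gives 13.5 ug/mL in an ADME assay on MT4 cells (Homo sapiens) for cytotoxicity, read by MTT assay, with a stated time of 5 days (on this read-out lower numbers stand for higher toxicity in this test and higher numbers for lower toxicity in this test), the lowest of the two numbers measured so far. Within the data shown here, its only neighbour, compound 1 `Cc1ccc2nc(Nn3c(-c4ccc([N+](=O)[O-])cc4)nnc3-c3cccnc3)sc2c1`, gives 64.4 ug/mL in this assay, and the one recorded step, a 4.8-fold lower number from compound 1 to compound 2 (0.68 log units; beyond the scatter), comes from putting 4-methyl-1,3-benzothiazol-2-yl in place of 6-methyl-1,3-benzothiazol-2-yl. Compound 3 `O=[N+]([O-])c1ccc(-c2nnc(-c3cccnc3)n2Nc2nc3c(Cl)cccc3s2)cc1` differs from compound 2 by chloro in place of methyl on an aromatic carbon. Among the measured compounds shown here, no measured pair exchanges one group for another at a fixed place; the single known step only exchanges one methyl-bearing group for another, so it gives no direct guide to chloro in place of methyl. With nothing pointing either way, the expectation for this assay is no step beyond the scatter, that is a 1.0-fold higher number from compound 2 to compound 3 (0.02 log units; within the scatter). Compound 3 is therefore estimated at 14 ug/mL, with a range from 5 ug/mL to 40 ug/mL.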

Compound 3, half-maximal cytotoxic concentration: 15.6 ug/mL
For compound 3 the middle estimate is 1.1-fold (0.05 log units) below the measured one; measured number inside the range.
By their numbers in this assay, from the lowest: compounds 2 and 3 (each within the scatter of the next); then compound 1.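

At the place named by 4-methyl-1,3-benzothiazol-2-yl, chloro in place of methyl gives a 1.2-fold higher number from compound 2 to compound 3 (0.06 log units; within the scatter) in this assay, so on this read-out the two groups cannot be told apart. The other step, a 4.1-fold lower number from compound 1 to compound 3 (0.62 log units; beyond the scatter), shows that compound 1 stays apart from the 4-substituted compounds whether that group is methyl or chloro, so the earlier gap was not tied to methyl alone. Nothing available explains why methyl and chloro read alike here.

The compounds shown leave open whether a larger or quite different group at this place, such as an amine, a methoxy group or a longer chain, would also leave the number unchanged. They also leave open whether 6-chloro-1,3-benzothiazol-2-yl would match the 6-methyl group of compound 1, as chloro matches methyl in the 4-substituted pair.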